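A few compounds are considered here, and "the series" means these few. Any claim that something is new, unique, unknown or untested is made for them only; others in the source may bear on it.

Series notes. Compound 1 `CCn1c(-c2cnc(C)nc2)nc2c(O[C@H]3CCN(C(=O)C4CC4)C3)ncnc21`, compound 2 `CCC(=O)N1CC[C@H](Oc2ncnc3c2nc(-c2cnc(C)nc2)n3CC)C1` and compound 3 `CCC(=O)N1CC[C@H](Nc2ncnc3c2nc(-c2cnc(C)nc2)n3CC)C1` have been measured in an ADME assay on LLC-PK1 cells (Sus scrofa) for permeability; a higher number here means that the compound crosses the layer faster, a lower number that the compound crosses the layer more slowly. In this assay compound 1 gives 28 10^-6 cm/s, compound 2 gives 21 10^-6 cm/s and compound 3 gives 21 10^-6 cm/s. Compound 1 and compound 2 differ in one place, (cyclopropyl in place of ethyl on a carbonyl carbon), and the step is a 1.3-fold higher number from compound 2 to compound 1 (0.12 log units; within the scatter). Compound 2 and compound 3 differ in their cores; that difference is not broken down here, and their numbers in this assay sit level at the digits given, so nothing separates them.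

Compound 4 `CCn1c(-c2cnc(C)nc2)nc2c(N[C@H]3CCN(C(=O)C4CC4)C3)ncnc21` has not yet been measured in this assay. It carries the core of compound 3 and differs from it by cyclopropyl in place of ethyl on a carbonyl carbon, which is the same change, at the same place, that turns compound 2 into compound 1. The step from compound 3 to compound 4 is expected to be a 1.2-fold higher number from compound 3 to compound 4 (0.09 log units; within the scatter), placed beside a 1.3-fold higher number from compound 2 to compound 1 (0.12 log units; within the scatter). This expectation rests on that single measured pair, compound 2 and compound 1, and on no other data. Compound 4 is therefore estimated at 26 10^-6 cm/s in this assay, with 17 10^-6 cm/s and 38 10^-6 cm/s as the ends of the expected range.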

Compound 4, apparent permeability in the LLC-PK1 assay: 22 10^-6 cm/s
The estimate for compound 4 lay 1.2-fold (0.07 log units) above the measured number; low and high end bracket the measured number.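

In the LLC-PK1 assay compound 3 gives 21 10^-6 cm/s and compound 4 gives 22 10^-6 cm/s. On the core of compound 3, cyclopropyl in place of ethyl on a carbonyl carbon gives in the LLC-PK1 assay a 1.0-fold higher number from compound 3 to compound 4 (0.02 log units; within the scatter), so the change stays within the scatter here, as it does on the core of compound 1. Set side by side, the two steps do not differ: the same change on two cores in the LLC-PK1 assay, a 1.3-fold higher number (0.12 log units; within the scatter) from compound 2 to compound 1 and a 1.0-fold higher number (0.02 log units; within the scatter) from compound 3 to compound 4, 1.3-fold (0.10 log units) apart, within the scatter of two such steps What this shows is that, on these two cores, the change leaves the read-out at a level that repeated measurement could not separate; it does not show that the change has an effect of its own on this read-out, that a small difference between the cores is absent, or that the same would hold on any further core. In a physicochemical assay for lipophilicity, read by HPLC (on this read-out higher numbers stand for higher lipophilicity and lower numbers for lower lipophilicity), compound 3 gives 0.7 and compound 4 gives 0.8, and the same change reads as a number 0.10 log units higher from compound 3 to compound 4 (within the scatter).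

The compounds shown carry only ethyl and cyclopropyl at this carbonyl, so a longer chain, a cyclobutyl ring or an amine in that place remains open. Also open, as far as these compounds go, is whether a group that gives a step beyond the scatter on one of these cores would give a matching step on the other.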